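The source may report more compounds than this note shows. Statements on the series, on what has been measured and on what is new or still open speak of the compounds shown alone.

Of the compounds shown here, three sharing one core have been measured in an ADME assay on the whole organism with Oryza sativa as the target, tested at 10 uM; on this read-out lower numbers stand for a stronger effect and higher numbers for a weaker effect at the one concentration tested. Compound 1 `C[C@@H](NC(=O)Nc1ccccc1Cl)c1ccccc1` gives 93%, compound 2 `C[C@@H](NC(=O)Nc1cccc(Cl)c1)c1ccccc1` gives 83%, and compound 3 `C[C@@H](NC(=O)Nc1cccc(I)c1)c1ccccc1` gives 73%. Compound 2 therefore stands second highest of the three, within the scatter of both of its neighbours. Compound 4 `C[C@@H](NC(=O)Nc1cccc(Cl)c1Cl)c1ccccc1` differs from compound 2 by chloro in place of hydrogen on an aromatic carbon, the entering chloro sitting ortho to the chloro group already present. Among the measured compounds shown here, the only measured step that bears on this is a number 10 percentage points lower from compound 2 to compound 3 (within the scatter), which swaps one halogen for another rather than adding one, so it offers little guidance, and no step beyond the scatter is expected. For compound 4 a value of 80% is estimated, within a range from 65% to 95%. The expected step is a number 3 percentage points lower from compound 2 to compound 4 (within the scatter).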

Compound 4, a percentage reported as activity, at one concentration (the size of the read-out at that concentration, not a potency): 99%
The estimate for compound 4 lay 19 percentage points below the measured number; the whole stated range lies below it.
By their numbers in this assay, from the lowest: compounds 3, 2, 1 and 4 (each within the scatter of the next, the first and the last beyond it).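

In this assay, chloro in place of hydrogen, ortho to a chloro group, gives a number 16 percentage points higher from compound 2 to compound 4 (beyond the scatter), the first step shown that lies beyond the scatter, and it points to a weaker effect. The same change, read from the other parent, gives a number 6 percentage points higher from compound 1 to compound 4 (within the scatter), so adding this chloro does not register equally from both compounds. Nothing available explains this difference. As far as these compounds go, whether a chloro is needed for this step stays open, since a fluoro, methyl or methoxy group at this place could give a different number.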